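Trading tert-butyl for trifluoromethyl on the shared core

The compounds below may be only part of what the source reports. "The series", "measured", "known", "first", "only" and "open" are said of these compounds alone.

In a functional assay on K562 cells (Homo sapiens) for cytotoxicity, read by MTT assay, with a stated time of 24 h (a lower number here means a stronger inhibitor, a higher number a weaker inhibitor), compound 3 (`CN1C/C(=C\c2ccc(C(C)(C)C)cc2)C(=O)/C(=C/c2ccccc2F)C1`) gives 18200 nM and stands level with compound 1 (`COc1ccc(/C=C2\CN(C)C/C(=C\c3ccccc3F)C2=O)cc1`) at 18400 nM while compound 2 (`COc1cc(/C=C2\CN(C)C/C(=C\c3ccccc3F)C2=O)cc(OC)c1`) shows a lower number at 6320 nM among the three measured. Compound 4 (`CN1C/C(=C\c2ccc(C(F)(F)F)cc2)C(=O)/C(=C/c2ccccc2F)C1`) has not yet been measured. It carries trifluoromethyl in place of tert-butyl on an aromatic carbon and is otherwise the same as compound 3. Among the measured compounds shown here, no measured step makes this exact exchange, so the evidence is thin. For the measured compounds named here, the one step that bears on it is a 1.0-fold lower number from compound 1 to compound 3 (0.00 log units; within the scatter) with tert-butyl in place of methoxy on an aromatic carbon. That step shows no movement beyond the scatter, and nothing measured yet tests trifluoromethyl itself. An estimated 1.1-fold lower number from compound 3 to compound 4 (0.06 log units; within the scatter) is therefore expected in this assay with no shift beyond the scatter anticipated. For compound 4 the estimate is 16000 nM with an expected range from 7000 nM to 32000 nM in this assay as the likely outcome.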

Compound 4, half-maximal inhibitory concentration: 6340 nM
Estimate against measurement, compound 4: 2.5-fold (0.40 log units) above; the measured number lies below the stated range.
By their numbers in this assay, from the lowest: compounds 2 and 4 (each within the scatter of the next); then compounds 3 and 1 (each within the scatter of the next).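

In this assay, the aromatic carbon carrying these groups had looked indifferent, since methoxy and tert-butyl could not be told apart there, but it now responds to the group it carries: trifluoromethyl gives a 2.9-fold lower number from compound 3 to compound 4 (0.46 log units; beyond the scatter) and a 2.9-fold lower number from compound 1 to compound 4 (0.46 log units; beyond the scatter), both modest and beyond the scatter. The exchange with tert-butyl keeps the heavy-atom count of the group and changes no ring, donor or acceptor count, so those counts do not separate the two compounds, and what differs is carbon replaced by fluorine in the group. Nothing measured here accounts for the shift.

The compounds shown leave open how a nitrile, an amine or a carboxylic acid on the same aromatic carbon would compare with trifluoromethyl. They also leave open whether this step would hold on a different core.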